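Swapping the Ring on the Thiocarbonyl Carbon

The source may hold more compounds than are shown below. What is called first, only, known or untested is meant among the compounds shown, and "the series" means these compounds.

Compound 2 `O=c1cc(CSC(=S)N2CCCC2)oc2ccccc12` gives the higher of the two numbers measured in a functional assay on SW480 cells (Homo sapiens) for antiproliferative activity, read by MTT assay, with a stated time of 72 h; on this read-out lower numbers stand for stronger inhibition and higher numbers for weaker inhibition: compound 2 gives 23400 nM. Among the compounds with values here, compound 1 `O=c1c(Cl)c(CSC(=S)N2CCOCC2)oc2ccccc12` gives 1800 nM in this assay, but compound 1 differs from compound 2 in two places at once, so the pair shows only that compound 1 sits far lower. Compound 3 `O=c1cc(CSC(=S)N2CCCC2)oc2cc(Cl)ccc12` carries a chloro on an aromatic carbon of the shared core. In this assay compound 3 gives > 25000 nM, which is a limit of the assay rather than a number. The step of an at least 1.0-fold higher number from compound 2 to compound 3 (0.02 log units; that floor lies within the scatter) is thus set by the limit of > 25000 nM in this assay, at which 1 of the 3 values shown sits, and stays within the scatter.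

Compound 4 `O=c1cc(CSC(=S)N2CCOCC2)oc2ccccc12` differs from compound 2 at a single place: morpholin-4-yl in place of pyrrolidin-1-yl on a thiocarbonyl carbon. Within the data shown here, no measured pair differs by this change alone, and the one measured step, an at least 1.0-fold higher number from compound 2 to compound 3 (0.02 log units; that floor lies within the scatter), concerns a chloro and carries no information about the ring on the thiocarbonyl carbon. Compound 1 also bears morpholin-4-yl and gives a far lower number than compound 2, yet it carries a chloro too, so its value cannot be assigned to the ring swap. Compound 4 is therefore expected to give 8000 nM, between 2000 nM and 25000 nM. This amounts to an expected step of a 2.9-fold lower number from compound 2 to compound 4 (0.47 log units; beyond the scatter), with wide uncertainty.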

Compound 4, half-maximal inhibitory concentration: 24400 nM
Compound 4: middle estimate off by 3.1-fold (0.48 log units), on the low side; measured number inside the range.
By their numbers in this assay, from the lowest: compound 1; then compounds 2 and 4 (each within the scatter of the next). At a limit, above all of these: compound 3.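

In this assay, morpholin-4-yl in place of pyrrolidin-1-yl on a thiocarbonyl carbon leaves the number unchanged on the core without a chloro, with the step reading a 1.0-fold higher number from compound 2 to compound 4 (0.02 log units; within the scatter). With morpholin-4-yl held fixed, the chloro can now be judged on its own, and taking it away gives a 14-fold higher number from compound 1 to compound 4 (1.13 log units; beyond the scatter), so the low number of compound 1 goes with its chloro and not with its morpholin-4-yl ring. A chloro on an aromatic carbon therefore does not behave alike on the two cores, and the gap between its two steps is larger than the scatter of such steps:  the same change on two cores in this assay, an at least 1.0-fold higher number (0.02 log units; that floor lies within the scatter) from compound 2 to compound 3 and a 14-fold lower number (1.13 log units; beyond the scatter) from compound 4 to compound 1, at least 14-fold (1.16 log units) apart, beyond the scatter of two such steps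

As far as these compounds go, compound 3 gives > 25000 nM, which is a limit of the assay and not a number, so the true size of its step stays unknown. Still open, from the compounds shown here alone, is whether the large step seen with the chloro holds with pyrrolidin-1-yl on the thiocarbonyl carbon, whether a bromo or a methyl group on that same aromatic carbon could take the place of the chloro, and whether a piperidin-1-yl ring or an open-chain diethylamino group would also leave the number unchanged.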